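This account rests on a few compounds, and the source may have more. Where it says the series, first, only, none or still open, it means among the compounds named here.

Of the compounds shown here, three sharing one core have so far been measured in an ADME assay on Vero cells (Chlorocebus sabaeus) for cytotoxicity, read by luminescence, with a stated time of 2 days; on this read-out higher numbers stand for lower toxicity in this test and lower numbers for higher toxicity in this test. Compound 1 `CCc1nc2ccccc2n1CCCCOc1ccccc1C(C)C` gives 19 uM, compound 2 `CCc1nc2ccccc2n1CCCCOCc1ccccc1` gives 32 uM, and compound 3 `CCc1nc2ccccc2n1CCCCOc1ccccc1Cl` gives 16 uM. Compound 2 holds the highest of the three numbers, yet its gaps to compound 1 and to compound 3 both lie within the scatter, so the three stand on one level. Compound 4 `CCc1nc2ccccc2n1CCCCOc1ccc(Cl)cc1Cl` differs from compound 2 by 2,4-dichlorophenyl in place of benzyl on an oxygen on a saturated carbon. Among the measured compounds shown here, two measured steps bear on this change: the step of a 2.0-fold lower number from compound 2 to compound 3 (0.30 log units; within the scatter), which also puts a chlorine-bearing phenyl in place of the benzyl, and the step of a 1.2-fold lower number from compound 1 to compound 3 (0.07 log units; within the scatter), chloro in place of isopropyl on an aromatic carbon. Neither moved the number beyond the scatter. For the measured compounds named here, the second chlorine in compound 4 has no measured counterpart. For compound 4 in this assay a value of 13 uM is therefore expected. The expected range for compound 4 runs from 6 uM to 30 uM. This amounts to an expected step of a 2.5-fold lower number from compound 2 to compound 4 (0.39 log units; beyond the scatter), at the edge of the scatter.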

Compound 4, half-maximal toxic concentration: 23 uM
Compound 4: middle estimate off by 1.8-fold (0.25 log units), on the low side; the measured number falls inside the stated range.
By their numbers in this assay, from the lowest: compounds 3, 1, 4 and 2 (each within the scatter of the next).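

With 2,4-dichlorophenyl in place of benzyl on the oxygen, this assay gives a 1.4-fold lower number from compound 2 to compound 4 (0.14 log units; within the scatter) and thus shows that this change, like the earlier exchange of benzyl for 2-chlorophenyl, stays within the scatter. Among the compounds shown here, the added chloro, the one change that had no measured counterpart, gives a 1.4-fold higher number from compound 3 to compound 4 (0.16 log units; within the scatter) and so cannot be told apart from the single chlorine in this test, which leaves all four compounds on one level whichever of these groups sits on the oxygen. No evidence is at hand that would explain this flat picture.

Still open, from the compounds shown here alone, is whether the number stays on this level with an amine or a carboxylic acid on the aromatic ring in place of chloro. The four compounds also cannot say whether a longer chain on the core would move it beyond the scatter.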